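Chloro to hydrogen on the hydroxyphenylmethyl side chain

The compounds below may be only part of what the source reports. "The series", "measured", "known", "first", "only" and "open" are said of these compounds alone.

Working notes on a small set built on one shared core. Among the compounds with values here, compound 1 `N#Cc1ccn2c(-c3ccccc3)c(-c3ccccc3)c(OCOCc3ccccc3)c2c1` is the only member with a number: in an assay for inhibition of Polyunsaturated fatty acid lipoxygenase ALOX15 (Oryctolagus cuniculus) (a higher number here means a weaker inhibitor, a lower number a stronger inhibitor), compound 1 gives 39000 nM, a weak result. Compound 2 `COc1ccc(C(O)c2c(-c3ccccc3)c(-c3ccccc3)n3ccc(C#N)cc23)cc1` carries a hydroxy(4-methoxyphenyl)methyl group on the same core; in this assay compound 2 gives "not determined" (no result reported). Compound 3 `N#Cc1ccn2c(-c3ccccc3)c(-c3ccccc3)c(C(O)c3ccc(Cl)cc3)c2c1` carries a (4-chlorophenyl)(hydroxy)methyl group; in this assay compound 3 gives "not determined" (no result reported). Compound 3 therefore stands without a number, as does compound 2, and the only anchor for the series is compound 1.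

Compound 4 `N#Cc1ccn2c(-c3ccccc3)c(-c3ccccc3)c(C(O)c3ccccc3)c2c1` differs from compound 3 as follows: hydrogen in place of chloro on an aromatic carbon. Within the data shown here, no step between two measured compounds is available for this series, so the size of the step from compound 3 to compound 4 in this assay cannot be read from data; the expectation is a step of no more than the usual scatter, in no set direction.

Among the measured compounds shown here, for compound 4 in this assay the estimate, resting on compound 1 at 39000 nM as the only measured member of the same core, is 30000 nM, with a range from 8000 nM to 120000 nM.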

Compound 4, half-maximal inhibitory concentration: 48000 nM
Estimate against measurement, compound 4: 1.6-fold (0.20 log units) below; measured number inside the range.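

In this assay, within the data shown here, hydroxy(phenyl)methyl and (benzyloxy)methoxy on the same aromatic carbon of the shared core give values that cannot be told apart, with a 1.2-fold higher number from compound 1 to compound 4 (0.09 log units; within the scatter); compound 4 at 48000 nM thus gives the hydroxy(aryl)methyl side chain its first number, and that number is as weak as the one for compound 1 at 39000 nM. Compound 2 and compound 3 have no reported result, so the steps from them to compound 4 cannot be read, and the change from chloro to hydrogen still has no measured size. No evidence on why the two side chains read alike is available.

Open, from the compounds shown here alone, is whether any replacement at this position can move the value beyond the scatter, for example an amine or a carboxylic acid on the phenyl ring, or a longer chain in place of the whole hydroxy(phenyl)methyl group. Also open, going by these compounds, is what a carbonyl in place of the hydroxy-bearing carbon would give on this core.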